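This account rests on a few compounds, and the source may have more. Where it says the series, first, only, none or still open, it means among the compounds named here.

Compound 1, `COc1cc2nc(N3CCN(C(=O)/C=C/c4ccc(F)cc4)CC3)nc(N)c2cc1OC`, gives 22.9 nM in an assay on cell membranes for displacement of a labelled ligand from Adrenergic receptor alpha-1 (Rattus norvegicus), tested at 100 nM; on this read-out lower numbers stand for stronger inhibition and higher numbers for weaker inhibition.
Compound 2, `COc1cc2nc(N3CCN(C(=O)/C=C/c4ccc(N=C=S)cc4)CC3)nc(N)c2cc1OC`, gives 102 nM.

Going by the values given here, compound 2 stands highest of the two numbers; the only other number is lower, and the step between them was a 4.5-fold higher number from compound 1 to compound 2 (0.65 log units; beyond the scatter). Compound 3, `COc1cc2nc(N3CCN(C(=O)/C=C/c4ccc(NC(=O)CBr)cc4)CC3)nc(N)c2cc1OC`, differs from compound 2 in one place: a group of 5 heavy atoms (2 carbon, 1 nitrogen, 1 oxygen, 1 bromine; no ring) in place of a group of 3 heavy atoms (1 carbon, 1 nitrogen, 1 sulfur; no ring), on an aromatic carbon. Among the compounds with values here, one measured step bears on this change, as it alters the same aromatic carbon; it was a modest rise. A further, larger replacement there is expected to move this assay in the same direction or stay within the scatter. For compound 3 the expected step is a 1.5-fold higher number from compound 2 to compound 3 (0.17 log units; within the scatter). Compound 3 is estimated at 150 nM, within 50 nM to 450 nM.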

Compound 3, half-maximal inhibitory concentration: 67.6 nM
Estimate against measurement, compound 3: 2.2-fold (0.35 log units) above, within the range that was stated.
By their numbers in this assay, from the lowest: compound 1; then compounds 3 and 2 (each within the scatter of the next).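

Replacing the group on this aromatic carbon with ((bromomethyl)carbonyl)amino gives a 1.5-fold lower number from compound 2 to compound 3 (0.18 log units; within the scatter), so in this assay these two larger groups cannot be told apart. Measured against fluoro, the same group gives a 3.0-fold higher number from compound 1 to compound 3 (0.47 log units; beyond the scatter), so both larger groups now give higher numbers than fluoro, not just one. Nothing available explains these differences. Still open, going by these compounds, is whether a small group such as an amine or a carboxylic acid at this carbon would match fluoro, and whether a longer chain would raise the number further.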